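Amino on the core of compound 1

A few compounds are considered here, and "the series" means these few. Any claim that something is new, unique, unknown or untested is made for them only; others in the source may bear on it.

Within the data shown here, in an ADME assay on L1210/0 cells (Mus musculus) for cytotoxicity, with a stated time of 48 h (on this read-out lower numbers stand for stronger inhibition and higher numbers for weaker inhibition), compound 1 (`CC(=O)OCCOCn1cnc2c(Cl)ncnc21`) gives 163000 nM, the only actual number in this small set. Compound 2 (`Nc1ncnc2c1ncn2C[C@@H]1C[C@H](CO)c2ccccc21`) reads > 200000 nM, which is a limit of the assay. Compound 3 (`C[C@@]1(CO)O[C@H](c2ccc(N)cc2F)C[C@@H]1O`) reads > 200000 nM, also a limit. Compound 4 (`CC(=O)OCCOCn1cnc2c(Cl)nc(N)nc21`) has amino in place of hydrogen on an aromatic carbon of the core of compound 1: amino in place of hydrogen on an aromatic carbon. Among the measured compounds shown here, no measured pair shows this change, so the expectation starts from compound 1 at 163000 nM and is only a modest shift toward stronger inhibition, close to the scatter. The expected step is a 1.5-fold lower number from compound 1 to compound 4 (0.17 log units; within the scatter). For compound 4 the estimated value is 110000 nM, with an expected range from 35000 nM to 200000 nM.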

Compound 4, half-maximal inhibitory concentration: > 200000 nM
Compound 4: only a limit was reported (the forecaster's own chance of this, stated with the estimate: 25%); middle value at least 1.8-fold (0.25 log units) from the limit.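

The amino group on this aromatic carbon, between two ring nitrogen atoms, reads as an at least 1.2-fold higher number from compound 1 to compound 4 (0.08 log units; that floor lies within the scatter) in this assay. This position therefore shows no stronger inhibition with amino in place of hydrogen, which compound 1 alone could not show. The true size of the step stays unreadable, since the reading for compound 4 is capped: the limit of > 200000 nM in this assay, at which 3 of the 4 values shown sit.

The compounds shown leave open whether amino shifts the number beyond the scatter. They also leave open what a hydroxyl or a dimethylamino group does on this aromatic carbon.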